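Trimming the amine side group of compound 2

A few compounds are considered here, and "the series" means these few. Any claim that something is new, unique, unknown or untested is made for them only; others in the source may bear on it.

- compound 1 `COc1cc(Oc2cccc(Nc3ccccc3)c2)cc(OC)c1CNCCNC(C)=O` gives 6010 nM
- compound 2 `COc1cc(Oc2cccc(Nc3ccccc3)c2)cc(OC)c1CNCc1ccc(C)cc1` gives 6080 nM

Both numbers come from a functional assay on DLD-1 cells (Homo sapiens) for inhibition, read by MTT assay, with a stated time of 72 h (a higher number here means a weaker inhibitor, a lower number a stronger inhibitor), and both compounds share one core. On these numbers compound 2 has a single measured neighbour, and the step between them is a 1.0-fold higher number from compound 1 to compound 2 (0.01 log units; within the scatter) with no real separation.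

Compound 3 `COc1cc(Oc2cccc(Nc3ccccc3)c2)cc(OC)c1CN(C)C` has not been measured yet. It carries dimethylamino in place of (4-methylbenzyl)amino on a saturated chain carbon bound to an aromatic carbon.

Among the measured compounds shown here, only one measured step bears on this change. It put 4-methylphenyl in place of acetamidomethyl on a saturated chain carbon bound to an amine nitrogen, so two quite different ends on the amine gave matching numbers. For the measured compounds named here, that is a single pair, and no compound with dimethylamino has been measured. The expectation therefore stays close to compound 2 at 6080 nM with no step beyond the scatter expected in this assay and with a wide range.

The expected step is a 1.2-fold higher number from compound 2 to compound 3 (0.06 log units; within the scatter) and it is small. For compound 3 the estimated value is 7000 nM with an expected range from 2500 nM to 20000 nM as its upper end.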

Compound 3, half-maximal inhibitory concentration: > 20000 nM
Compound 3: a limit, no number (the forecaster's own chance of this, stated with the estimate: 10%); middle value at least 2.8-fold (0.45 log units) away from the limit.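

In this assay compound 3 gives a limit of the assay and not a number: the limit of > 20000 nM in this assay, at which 1 of the 3 values shown sits.

Compounds 1 and 2 alone suggested that the amine side group could be changed freely, but this change does register, with an at least 3.2-fold higher number from compound 2 to compound 3 (0.51 log units; beyond the scatter) and an at least 3.3-fold higher number from compound 1 to compound 3 (0.52 log units; beyond the scatter). The group on the saturated chain carbon bound to an aromatic carbon therefore matters to the reading, although two quite different ends on the amine gave matching values. Here (4-methylbenzyl)amino, with 9 heavy atoms, a ring and 1 hydrogen-bond donor, gives way to dimethylamino, with 3 heavy atoms, no ring and 0 hydrogen-bond donors, so several features change in one step.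

These three compounds cannot show which of those differences counts, or how far the value of compound 3 lies past its limit. Methylamino would keep the amine hydrogen on a short group, while N-methyl-(4-methylbenzyl)amino would remove that hydrogen and keep the ring, so this pair could pull the two features apart.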